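The source may report more compounds than this note shows. Statements on the series, on what has been measured and on what is new or still open speak of the compounds shown alone.

Compound 1, `NC/C=C\COc1ccccc1`: in an assay on isolated protein for inhibition of Amine oxidase [copper-containing] 3 (Homo sapiens), read by Amplex Red (a higher number here means a weaker inhibitor, a lower number a stronger inhibitor), compound 1 gives > 100000 nM, which is a limit of the assay and not a number.
Compound 2, `NC/C=C/COc1ccccc1`: compound 2 gives 82000 nM.
Compound 3, `COc1ccc(OC/C(F)=C\CN)cc1`: compound 3 gives 160 nM.

Of the two numbers recorded, compound 3 gives the lowest, and its gap to compound 2 lies well beyond the usual scatter of this assay. Compounds 1 and 2 share all atoms and bonds and differ only in the drawn configuration of the double bond, which is the matter of the fact that compounds 1 and 2 differ only in the configuration as drawn; the step of an at least 1.2-fold lower number from compound 1 to compound 2 (0.08 log units; that floor lies within the scatter) is read against the limit of > 100000 nM in this assay, at which 1 of the 3 values shown sits, and rests on a limit at one end.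

Compound 4, `NC/C=C(/F)COc1ccc(Oc2ccccc2)cc1`, has not yet been measured. It differs from compound 3 by phenyl in place of methyl on an oxygen on an aromatic ring. Neither measured step touches this part of the molecule: the only step recorded is a change of configuration, and the change from methyl to phenyl on that oxygen has no counterpart among the compounds shown. With nothing to weigh the change in either direction, the number for compound 4 is expected to stay close to that of compound 3, with a wide margin. Compound 4 is therefore estimated to give 150 nM in this assay, within the range 40 nM to 600 nM. That estimate means an expected step of a 1.1-fold lower number from compound 3 to compound 4 (0.03 log units; within the scatter), one that would fall within the scatter.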

Compound 4, half-maximal inhibitory concentration: 240 nM
Compound 4: middle estimate off by 1.6-fold (0.20 log units), on the low side; the measured number falls inside the stated range.
By their numbers in this assay, from the lowest: compounds 3 and 4 (each within the scatter of the next); then compound 2. At a limit, above all of these: compound 1.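

In this assay, within the data shown here, phenyl in place of methyl on an oxygen on an aromatic ring gives a 1.5-fold higher number from compound 3 to compound 4 (0.18 log units; within the scatter), so this place accepts a group of six carbon atoms with a six-membered aromatic ring in place of a single carbon, with no step that stands out from repeat measurements. The earlier compounds offered only a change of configuration, read against a limit, so this is the only step shown at this oxygen and the only step with a real number at both ends. Nothing in the information at hand accounts for the size of this step, or for how little the number moves with a group this much larger.

The compounds shown leave open how far this tolerance extends: benzyl or a longer chain on the same oxygen, or an amine or a carboxylic acid carried on the entering phenyl, could read quite differently in this assay. What the fluorine contributes also stays open, since no pair shown differs in that atom alone.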